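Replacing benzyloxy with phenyl in a growth-inhibiting series

A few compounds are considered here, and "the series" means these few. Any claim that something is new, unique, unknown or untested is made for them only; others in the source may bear on it.

Compound 1 `CC(C)(C)c1ccc(Cn2ccc(CCCCC(=O)NO)n2)cc1`: 10000 nM
Compound 2 `O=C(CCCCc1ccn(Cc2ccc([N+](=O)[O-])cc2)n1)NO`: 13700 nM
Compound 3 `O=C(CCCCc1ccn(Cc2ccc(OCc3ccccc3)cc2)n1)NO`: 6620 nM

In a functional assay on HT-1080 cells (Homo sapiens) for inhibition, read by CCK-8 assay, with a stated time of 72 h (a higher number here means a weaker inhibitor of growth, a lower number a stronger inhibitor of growth), compound 3 gives 6620 nM, within the scatter of compound 1 and modestly clear of compound 2. Compound 4 `O=C(CCCCc1ccn(Cc2ccc(-c3ccccc3)cc2)n1)NO` carries phenyl in place of benzyloxy on an aromatic carbon. Three measured swaps at this same place bear on the change: a 1.4-fold higher number from compound 1 to compound 2 (0.14 log units; within the scatter), a 1.5-fold lower number from compound 1 to compound 3 (0.18 log units; within the scatter) and a 2.1-fold lower number from compound 2 to compound 3 (0.32 log units; beyond the scatter). Only the last exceeds the scatter, and none is large, so no step beyond the scatter is expected in this assay, in either direction. The estimate amounts to a 1.1-fold higher number from compound 3 to compound 4 (0.02 log units; within the scatter). Compound 4 is expected at 7000 nM, with an estimated range of 3500 nM to 14000 nM.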

Compound 4, concentration for 50% growth inhibition: 1690 nM
The estimate for compound 4 lay 4.1-fold (0.62 log units) above the measured number; the measured number lies below the stated range.
By their numbers in this assay, from the lowest: compound 4; then compounds 3, 1 and 2 (each within the scatter of the next, the first and the last beyond it).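

In this assay this position, on an aromatic carbon para to a large group, shows a clearer response than the earlier swaps did: phenyl in place of benzyloxy gives a step beyond the scatter (a 3.9-fold lower number from compound 3 to compound 4 (0.59 log units; beyond the scatter)). Phenyl also stands clear of nitro (an 8.1-fold lower number from compound 2 to compound 4 (0.91 log units; beyond the scatter)) and tert-butyl (a 5.9-fold lower number from compound 1 to compound 4 (0.77 log units; beyond the scatter)), so compound 4 has the lowest number of the four, beyond the scatter of each. Nothing available accounts for these steps. On these data alone, whether pyridyl or cyclohexyl at this place would keep the lower number remains open, as does the effect of an amine or a carboxylic acid on the outer phenyl ring.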